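The compounds below may be only part of what the source reports. "The series", "measured", "known", "first", "only" and "open" are said of these compounds alone.

Working notes on a set sharing one core. Compound 1 `Nc1nc(N)c(CCCN(Cc2ccc(NC(CCC(=O)O)C(=O)O)cc2)c2cc(F)c([N+](=O)[O-])cc2[N+](=O)[O-])c(O)n1` in a functional assay on CCRF-CEM cells (Homo sapiens) for cytotoxicity, in the absence of a further agent (on this read-out higher numbers stand for weaker inhibition and lower numbers for stronger inhibition), gives 40000 nM. Compound 2 `Nc1nc(N)c(CCCN(Cc2ccc(NC(CCC(=O)O)C(=O)O)cc2)c2cc(F)c(F)cc2[N+](=O)[O-])c(O)n1` in this assay returns only > 100000 nM, which is a limit of the assay and not a number. Compound 3 `Nc1nc(N)c(CCCN(Cc2ccc(NC(CCC(=O)O)C(=O)O)cc2)c2ccc([N+](=O)[O-])c(F)c2F)c(O)n1` likewise returns only > 100000 nM, again a limit rather than a number. Compound 4 `Nc1nc(N)c(CCCN(Cc2ccc(NC(CCC(=O)O)C(=O)O)cc2)c2ccc([N+](=O)[O-])c(F)c2[N+](=O)[O-])c(O)n1` has not yet been measured. The step of an at least 2.5-fold lower number from compound 2 to compound 1 (0.39 log units; beyond the scatter) goes with the change (nitro in place of fluoro on an aromatic carbon). The step that the two limits leave unreadable from compound 2 to compound 3 goes with the core difference (2,3-difluoro-4-nitrophenyl in place of 4,5-difluoro-2-nitrophenyl on an amine nitrogen), its size unreadable since (the limit of > 100000 nM in this assay, at which 2 of the 3 values shown sit). Compound 4 is reached from compound 3 by nitro in place of fluoro on an aromatic carbon, the same kind of change as that from compound 2 to compound 1, though here the entering nitro sits ortho to a large group rather than para to a large group. A step of an at least 1.6-fold lower number from compound 3 to compound 4 (0.22 log units; that floor lies within the scatter) is expected, resting on the earlier at least 2.5-fold lower number from compound 2 to compound 1 (0.39 log units; beyond the scatter). Compound 4 is thus estimated at 60000 nM, with a range from 20000 nM to 150000 nM.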

Compound 4, half-maximal inhibitory concentration: 36000 nM
Beside the measured number, compound 4's estimate is 1.7-fold (0.22 log units) above it; the range from low to high includes it.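

In this assay, nitro in place of fluoro on an aromatic carbon gives an at least 2.7-fold lower number from compound 3 to compound 4 (0.44 log units; beyond the scatter). The direction of the change therefore carries across the two cores shown, though this rests on only one pair per core: the same change on two cores in this assay, an at least 2.5-fold lower number (0.39 log units; beyond the scatter) from compound 2 to compound 1 and an at least 2.7-fold lower number (0.44 log units; beyond the scatter) from compound 3 to compound 4; the limit leaves it open whether they differ. From the compounds shown here alone, both steps start from a limit, so their true sizes remain unknown, and the step between compound 2 and compound 3 cannot be read: the limit of > 100000 nM in this assay, at which 2 of the 4 values shown sit.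

The compounds shown leave open whether another group in the same place, such as a nitrile or a trifluoromethyl, would give a similar step. Going by these compounds, it also remains open whether the nitro step would hold on a core with a longer chain.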